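This account rests on a few compounds, and the source may have more. Where it says the series, first, only, none or still open, it means among the compounds named here.

Three compounds built on one shared core were tested in an ADME assay on THP-1 cells (Homo sapiens) for cytotoxicity, read by MTT assay, with a stated time of 72 h; on this read-out lower numbers stand for higher toxicity in this test and higher numbers for lower toxicity in this test. Compound 1 `O[C@@H]1Cc2cc(Cl)ccc2N[C@H](c2ccccc2Cl)C1` gives 75500 nM. For compound 2 `O[C@@H]1Cc2ccccc2N[C@H](c2c(Cl)cccc2Cl)C1` the result is only a limit, > 300000 nM. For compound 3 `O[C@@H]1Cc2ccccc2N[C@H](c2c(F)cccc2Cl)C1` the result is likewise a limit, > 300000 nM. Among the compounds with values here, the single measured step, a step that the two limits leave unreadable from compound 2 to compound 3, cannot be read because of the limit of > 300000 nM in this assay, at which 2 of the 3 values shown sit. Compound 2 therefore stands at that limit, with no number of its own. Compound 4 `O[C@@H]1Cc2cc(Cl)ccc2N[C@H](c2c(Cl)cccc2Cl)C1` differs from compound 2 by chloro in place of hydrogen on an aromatic carbon. Within the data shown here, no measured step covers this change; compound 1 carries chloro on the fused ring and returns a number, but it also differs from compound 2 elsewhere. Compound 4 is thus expected to show an at least 2.0-fold lower number from compound 2 to compound 4 (0.30 log units; that floor lies within the scatter). The estimate for compound 4 is 150000 nM, with a range from 50000 nM to 400000 nM.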

Compound 4, half-maximal cytotoxic concentration: 59600 nM
Compound 4: middle estimate off by 2.5-fold (0.40 log units), on the high side; the range from low to high includes it.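

In this assay, chloro in place of hydrogen on the aromatic ring of the fused system gives an at least 5.0-fold lower number from compound 2 to compound 4 (0.70 log units; beyond the scatter), so this position responds to the change, and the true step may be larger. On the other aromatic ring, the added chloro gives a 1.3-fold lower number from compound 1 to compound 4 (0.10 log units; within the scatter), so that change shows no clear shift once chloro already sits on the fused system. The compounds shown leave open whether this response is particular to chloro, as none carries a methoxy group, an amine or a carboxylic acid at this position.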